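This account rests on a few compounds, and the source may have more. Where it says the series, first, only, none or still open, it means among the compounds named here.

Measured compounds:
Compound 1, `NC1=NC2(CCSCC2)N(OCCCOc2cccc(Cl)c2)C(N)=N1`: 130 nM
Compound 2, `NC1=NC2(CCOCC2)N(OCCCOc2ccc(F)cc2)C(N)=N1`: "not determined" (no result reported)
Compound 3, `CC(C)(C)c1ccc(OCCCON2C(N)=NC(N)=NC23CCOCC3)cc1`: "not determined" (no result reported)

Within the data shown here, in a functional assay on MDA-MB-231 cells (Homo sapiens) for antiproliferative activity, read by MTT assay, with a stated time of 72 h (on this read-out higher numbers stand for weaker inhibition and lower numbers for stronger inhibition), compound 1 gives 130 nM, the only number in this set, as compound 2 and compound 3 carry no reported result. Compound 4, `NC1=NC2(CCSCC2)N(OCCCOc2ccccc2Cl)C(N)=N1`, differs from compound 1 in one place: 2-chlorophenyl in place of 3-chlorophenyl on an oxygen on a saturated carbon. Among the measured compounds shown here, no pair of measured compounds shows what such a change does here, so the expectation rests on the single value of compound 1 alone. A small step is expected for compound 4, likely within the usual scatter, with a slight lean toward weaker inhibition; the estimated step is a 1.5-fold higher number from compound 1 to compound 4 (0.19 log units; within the scatter). Compound 4 is therefore expected at 200 nM in this assay, with a range from 70 nM to 600 nM.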

Compound 4, half-maximal inhibitory concentration: 80 nM
For compound 4 the middle estimate is 2.5-fold (0.40 log units) above the measured one; the measured number falls inside the stated range.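

In this assay, among these compounds, the exchange of 3-chlorophenyl for 2-chlorophenyl on an oxygen on a saturated carbon gives a 1.6-fold lower number from compound 1 to compound 4 (0.21 log units; within the scatter) and so provides the first reading of any change at this position: on this read-out, the two chlorophenyl groups cannot be told apart. Nothing available speaks to a cause for this result.

The compounds shown leave open whether 4-chlorophenyl would read the same way. They also leave open what an amine or a carboxylic acid on the phenyl ring, or a longer chain before the oxygen, would do.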